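Methyl in Place of Hydrogen on a Ring Nitrogen

This account rests on a few compounds, and the source may have more. Where it says the series, first, only, none or still open, it means among the compounds named here.

Compound 1, with the structure `CCn1cc(-c2nc3ccc([N+](=O)[O-])cc3s2)c(=O)c2cc(F)c(N3CCNCC3)cc21`, and compound 2, with the structure `CCn1cc(-c2nc3ccc([N+](=O)[O-])cc3s2)c(=O)c2cc(F)c(N3CCN(C)CC3)cc21`, share one core and differ only in one place: methyl in place of hydrogen on an amine nitrogen in a ring. In a functional assay on Bel-7402 cells (Homo sapiens) for cytotoxicity, read by MTT assay, with a stated time of 48 h (a lower number here means a stronger inhibitor, a higher number a weaker inhibitor), compound 1 gives 1800 nM, while compound 2 gives 7700 nM, so the change produced a 4.3-fold higher number from compound 1 to compound 2 (0.63 log units; beyond the scatter).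

Compound 3, with the structure `CCn1cc(-c2nc3ccc(N)cc3[nH]2)c(=O)c2cc(F)c(N3CCNCC3)cc21`, carries a different core; the difference between the two cores is not broken down here. In this assay, among the measured compounds shown here, compound 3 gives 92100 nM, the highest of the three numbers so far.

Compound 4, with the structure `CCn1cc(-c2nc3ccc(N)cc3[nH]2)c(=O)c2cc(F)c(N3CCN(C)CC3)cc21`, has not yet been measured. It differs from compound 3 by methyl in place of hydrogen on an amine nitrogen in a ring, the same change that turned compound 1 into compound 2. Within the measured pair this change produced a 4.3-fold higher number from compound 1 to compound 2 (0.63 log units; beyond the scatter). If it behaves the same way here, the expected step is a 3.3-fold higher number from compound 3 to compound 4 (0.51 log units; beyond the scatter). On this basis compound 4 is expected to give about 300000 nM in this assay, estimated between 100000 nM and 1000000 nM. This rests on a single measured pair, and since compound 3 already shows a high number, the assay may well return only a limit for compound 4.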

Compound 4, half-maximal inhibitory concentration: > 50000 nM
Compound 4: no number, only a limit; the forecaster's own chance of this, stated with the estimate: 40%; the middle value does not contradict the limit.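

In this assay compound 4 gives > 50000 nM, which is a limit of the assay and not a number. The step from compound 3 to compound 4 cannot be read because the result is only a limit: the limit of > 50000 nM in this assay, at which 1 of the 4 values shown sits.

Still open, as far as these compounds go, is whether 4-methylpiperazin-1-yl in place of piperazin-1-yl shifts the number the same way on the core of compound 3 as on the core of compound 1.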